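Returning an aryl ring to the core of compound 2

This account rests on a few compounds, and the source may have more. Where it says the series, first, only, none or still open, it means among the compounds named here.

Measured so far:
compound 1 `Cc1cc(Sc2ccccc2Cl)c(S(C)(=O)=O)cc1C(=O)N=C(N)N`: 14 nM
compound 2 `Cc1cc(O)c(S(C)(=O)=O)cc1C(=O)N=C(N)N`: 220 nM

Both compounds were tested in a functional assay for inhibition of sodium/hydrogen exchanger (Oryctolagus cuniculus); on this read-out higher numbers stand for weaker inhibition and lower numbers for stronger inhibition; compound 1 gives 14 nM and compound 2 gives 220 nM. Among the measured compounds shown here, compound 2 stands at the higher of the two numbers, its only neighbour being compound 1. For the measured compounds named here, the single step between them, a 16-fold higher number from compound 1 to compound 2 (1.20 log units; beyond the scatter), came with hydroxy in place of (2-chlorophenyl)sulfanyl on an aromatic carbon.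

Compound 3 `Cc1cc(Oc2ccc(Cl)cc2)c(S(C)(=O)=O)cc1C(=O)N=C(N)N` has not yet been measured. It differs from compound 2 by 4-chlorophenyl in place of hydrogen on an oxygen on an aromatic ring. Going by the values given here, the only step that bears on this change is the one from compound 1 to compound 2, which was large. Compound 3 puts a chlorinated aromatic ring back at the same place, now through oxygen and as 4-chlorophenyl rather than 2-chlorophenyl, so a large move towards lower numbers is expected, though not necessarily the full reversal. Compound 3 is therefore estimated at 30 nM, with a range of 10 nM to 90 nM, an expected step of a 7.3-fold lower number from compound 2 to compound 3 (0.87 log units; beyond the scatter).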

Compound 3, half-maximal inhibitory concentration: 13 nM
Beside the measured number, compound 3's estimate is 2.3-fold (0.36 log units) above it; measured number inside the range.
By their numbers in this assay, from the lowest: compounds 3 and 1 (each within the scatter of the next); then compound 2.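

In this assay, placing 4-chlorophenyl on the oxygen of the hydroxy group brings a 17-fold lower number from compound 2 to compound 3 (1.23 log units; beyond the scatter) and so shows that this position can regain what was lost in the first step. The new comparison gives a 1.1-fold lower number from compound 1 to compound 3 (0.03 log units; within the scatter) and shows that 4-chlorophenoxy and (2-chlorophenyl)sulfanyl cannot be told apart here, although they differ in both the linking atom and the place of the chlorine. The compounds shown offer no evidence on why the aryl ring restores the number. From the compounds shown here alone, whether the linking atom and the place of the chlorine would each matter alone remains open, and 2-chlorophenoxy or 4-chlorophenylsulfanyl would address that. Also open, going by these compounds, is whether the chlorine or the aromatic ring is needed at all, a question for unsubstituted phenoxy or cyclohexyloxy.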